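From Fluoro to (Trifluoromethyl)sulfanyl: A Step Without a Starting Number

The source may report more compounds than this note shows. Statements on the series, on what has been measured and on what is new or still open speak of the compounds shown alone.

Two closely related compounds have so far gone through a functional assay on BGC-823 cells (Homo sapiens) for antiproliferative activity, read by MTT assay, with a stated time of 72 h; a lower number here means a stronger inhibitor, a higher number a weaker inhibitor. In this test, compound 1 (`O=C(Nc1cccc(Br)c1)C(Cl)Cl`) gives 95300 nM as its result. For compound 2 (`O=C(Nc1ccc(F)cc1)C(Cl)Cl`) the entry reads "not determined" (no result reported) and no number follows. Compound 2 therefore cannot be ranked against compound 1, and it offers no value from which to measure a change.

Compound 3 (`O=C(Nc1ccc(SC(F)(F)F)cc1)C(Cl)Cl`) has not yet been tested in this assay. The structural change leading to it is small to describe ((trifluoromethyl)sulfanyl in place of fluoro on an aromatic carbon): (trifluoromethyl)sulfanyl in place of fluoro on an aromatic carbon.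

Among the measured compounds shown here, no measured step between similar compounds exists here, so the size of this change cannot be read from the data. For the measured compounds named here, the only anchor is compound 1 at 95300 nM as a single reading. A modest step toward a lower number than that anchor is expected in this assay, though confidence in its direction is low. Compound 3 is estimated at 40000 nM (expected range 10000 nM to 120000 nM).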

Compound 3, half-maximal inhibitory concentration: 203000 nM
Estimate against measurement, compound 3: 5.1-fold (0.71 log units) below; the measured number lies above the stated range.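

No new step can be read here: compound 2 has no single number in this assay, and compound 3 differs from compound 1 in more than one place. The compounds shown leave open how far (trifluoromethyl)sulfanyl in place of fluoro shifts the result on this core. No measured evidence bears on this result.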